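From Cyclobutylsulfonyl to Diethylcarbamoyl at the Assay Limit

This account rests on a few compounds, and the source may have more. Where it says the series, first, only, none or still open, it means among the compounds named here.

Of the compounds shown here, two have so far been tested in a functional assay on MIA PaCa-2 cells (Homo sapiens) for inhibition, read by MTT assay, with a stated time of 3 days; on this read-out lower numbers stand for stronger inhibition and higher numbers for weaker inhibition. Compound 1 (`CCN(CC)S(=O)(=O)c1ccc(S(=O)(=O)N2CCC[C@@H](C(=O)NC3CN(C(=O)C4CC4)C3)C2)cc1`) gives > 10000 nM, which is a limit and not a number. Compound 2 (`CC(C)c1noc(N2CCN(C(=O)[C@@H]3CCCN(S(=O)(=O)c4ccc(S(=O)(=O)C5CCC5)cc4)C3)CC2)n1`) gives > 10000 nM, which is also a limit. The record so far therefore comes down to the limit of > 10000 nM in this assay, at which 2 of the 2 values shown sit, and compound 2 stands there with no measured number of its own. Going by the values given here, no step between measured compounds is available to show how far a change can move the result.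

Compound 3 (`CCN(CC)C(=O)c1ccc(S(=O)(=O)N2CCC[C@@H](C(=O)N3CCN(c4nc(C(C)C)no4)CC3)C2)cc1`) keeps the rest of compound 2 and carries diethylcarbamoyl in place of cyclobutylsulfonyl on an aromatic carbon, para to a large group: diethylcarbamoyl in place of cyclobutylsulfonyl on an aromatic carbon. The expectation rests on compound 2, whose > 10000 nM is a limit. The expected change is a number no higher from compound 2 to compound 3 (the limit leaves the size open), which means none beyond the scatter. In this assay the estimate for compound 3 is 10000 nM, within an expected range from 4000 nM to 30000 nM.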

Compound 3, half-maximal inhibitory concentration: > 10000 nM
Compound 3: no number, only a limit; the forecaster's own chance of this, stated with the estimate: 80%; the middle value sits exactly at the limit.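

Compound 2 and compound 3 both give only limits and no numbers, so no new step can be read between them. The record stays where it stood: the limit of > 10000 nM in this assay, at which 3 of the 3 values shown sit.

The compounds shown leave open whether any change in this series can yield a measured number in this assay, and how compound 1, compound 2 and compound 3 compare.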